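Working notes: isopropyl to tert-butyl on the shared core

The source may report more compounds than this note shows. Statements on the series, on what has been measured and on what is new or still open speak of the compounds shown alone.

Compound 2 `CC(C)c1cc(/C=C/C(=O)c2ccco2)cc(/C=N/c2nccs2)c1O` gives 60000 nM in an ADME assay on Vero cells (Chlorocebus sabaeus) for cytotoxicity, using serial dilution; a higher number here means that more compound is tolerated, a lower number that less compound is tolerated. Among the compounds with values here, only one other number is in hand: compound 1 `CC(C)(C)c1cc(/C=C/C(=O)c2cccs2)cc(/C=N/c2nccs2)c1O` gives 40000 nM in this assay, and the gap between compound 1 and compound 2 lies within the scatter, so the two cannot be told apart on tolerance. Within the data shown here, compound 1 also differs from compound 2 in more than one place, so no single structural step between measured compounds is available.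

Compound 3 `CC(C)(C)c1cc(/C=C/C(=O)c2ccco2)cc(/C=N/c2nccs2)c1O` is not yet measured. It differs from compound 2 by methyl in place of hydrogen on a saturated chain carbon bound to an aromatic carbon and two saturated chain carbons, with the shared core otherwise unchanged. The step from compound 2 to compound 3 is expected to be none beyond the scatter, in either direction, as a 1.2-fold lower number from compound 2 to compound 3 (0.08 log units; within the scatter) expresses. This expectation rests on compound 1, which carries the tert-butyl group and gives 40000 nM in this assay, within the scatter of compound 2. For compound 3 the estimate in this assay is 50000 nM, with a range of 25000 nM to 100000 nM.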

Compound 3, half-maximal cytotoxic concentration: 220000 nM
Compound 3: middle estimate off by 4.4-fold (0.64 log units), on the low side; the measured number lies above the stated range.
By their numbers in this assay, from the lowest: compounds 1 and 2 (each within the scatter of the next); then compound 3.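

In this assay the change from isopropyl to tert-butyl on the shared core is a step beyond the scatter at this saturated chain carbon (a 3.7-fold higher number from compound 2 to compound 3 (0.56 log units; beyond the scatter)), which the gap between compound 1 and compound 2 could not show. With tert-butyl held in place, the group on the carbonyl carbon also matters, as furan-2-yl in place of thiophen-2-yl gives a step beyond the scatter too (a 5.5-fold higher number from compound 1 to compound 3 (0.74 log units; beyond the scatter)). Nothing measured on these compounds bears on what lies behind either step.

Open is whether the step from isopropyl to tert-butyl holds with thiophen-2-yl on the carbonyl carbon, as the compounds shown pair that group only with tert-butyl. Also open, on these data alone, is how a longer chain or an amine at this saturated chain carbon would read in this assay against tert-butyl.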